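Trimethoxyphenyl Replaces Methoxyphenyl on the Shared Core

The compounds below may be only part of what the source reports. "The series", "measured", "known", "first", "only" and "open" are said of these compounds alone.

Compound 1 `COc1cc(/C=C/C(=O)c2cccc(-n3cc(-c4ccccc4)[nH]c3=O)c2)cc(OC)c1OC` and compound 2 `COc1ccc(-c2cn(-c3cccc(C(=O)/C=C/c4cc(OC)c(OC)c(OC)c4)c3)c(=O)[nH]2)cc1` share a core in which a chalcone-type chain carries a ring that bears a substituted phenyl group. In a functional assay on PC-3 cells (Homo sapiens) for inhibition (on this read-out lower numbers stand for stronger inhibition of growth and higher numbers for weaker inhibition of growth), compound 1 gives 3260 nM. In this assay, within the data shown here, compound 2 gives 6220 nM, the highest of the two numbers so far, with compound 1 as its nearest neighbour. Among the measured compounds shown here, the one measured step, a 1.9-fold higher number from compound 1 to compound 2 (0.28 log units; within the scatter), shows that adding a single methoxy group to that phenyl ring did not move the number beyond the usual scatter.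

Compound 3 `COc1cc(/C=C/C(=O)c2cccc(-n3cc(-c4cc(OC)c(OC)c(OC)c4)[nH]c3=O)c2)cc(OC)c1OC` takes this change further: 3,4,5-trimethoxyphenyl in place of 4-methoxyphenyl on an aromatic carbon. For the measured compounds named here, the only step that bears on it is the methoxy addition from compound 1 to compound 2, which was within the scatter. Two more methoxy groups on the same ring are therefore expected to give at most a small step in this assay, likely toward a slightly higher number, since that is the direction the single methoxy already leaned. Compound 3 is estimated at 8000 nM, in a range from 3000 nM to 22000 nM, which means an expected step of a 1.3-fold higher number from compound 2 to compound 3 (0.11 log units; within the scatter).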

Compound 3, concentration for 50% growth inhibition: 2630 nM
Beside the measured number, compound 3's estimate is 3.0-fold (0.48 log units) above it; the whole stated range lies above it.
By their numbers in this assay, from the lowest: compounds 3, 1 and 2 (each within the scatter of the next, the first and the last beyond it).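

Among these compounds, the 3,4,5-trimethoxyphenyl group in place of 4-methoxyphenyl, on the aromatic carbon of the five-membered ring, gives the first step beyond the scatter in this assay (a 2.4-fold lower number from compound 2 to compound 3 (0.37 log units; beyond the scatter)), although it is a modest one, so this position does register what the attached phenyl ring carries. Measured against the plain phenyl group of compound 1, however, the same trimethoxyphenyl group stays within the scatter (a 1.2-fold lower number from compound 1 to compound 3 (0.09 log units; within the scatter)), so the phenyl ring with no methoxy and the ring with three cannot be told apart here. Among the compounds shown here, the methoxy count therefore shows no steady trend across these three compounds: the single clear gap is the one between compound 2 and compound 3, and even that gap rests on one pair. No measurement offered here explains why the step from compound 2 to compound 3 runs in this direction. Going by these compounds, what a hydroxyl, an amine or a carboxylic acid on this phenyl ring would do remains open. On these data alone, it is also open whether a ring with two methoxy groups would fall with compound 2 or with compound 3.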